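Swapping the styryl arm for a dimethoxyphenyl ring

The source may report more compounds than this note shows. Statements on the series, on what has been measured and on what is new or still open speak of the compounds shown alone.

Among the measured compounds shown here, compound 2 `Cc1cc(O)c(C2=NN(c3ccc(S(N)(=O)=O)cc3)C(/C=C/c3ccccc3)C2)cc1Cl` gives 87700 nM in a functional assay on CAKI-1 cells (Homo sapiens) for antiproliferative activity, with a stated time of 48 h (on this read-out higher numbers stand for weaker inhibition of growth and lower numbers for stronger inhibition of growth), the highest of the two numbers known, with compound 1 `Cc1cc(O)c(C2=NN(c3ccc(S(N)(=O)=O)cc3)C(c3ccccc3O)C2)cc1Cl` as its only neighbour at 4440 nM. For the measured compounds named here, the one measured step, a 20-fold higher number from compound 1 to compound 2 (1.30 log units; beyond the scatter), shows how much the replacement of a directly attached aryl by a 2-phenylethenyl group cost. Compound 3 `COc1ccc(C2CC(c3cc(Cl)c(C)cc3O)=NN2c2ccc(S(N)(=O)=O)cc2)cc1OC` reverses that kind of change: 3,4-dimethoxyphenyl in place of 2-phenylethenyl on a saturated ring carbon. Because that earlier step, a 20-fold higher number from compound 1 to compound 2 (1.30 log units; beyond the scatter), was large, a substantial move back toward lower numbers is expected here, though the new ring carries methoxy groups rather than the hydroxyl of compound 1, so a full return is not assumed. The expected step of an 8.8-fold lower number from compound 2 to compound 3 (0.94 log units; beyond the scatter) is therefore a clear fall. Compound 3 is estimated at 10000 nM in this assay, within a range of 3000 nM to 40000 nM.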

Compound 3, concentration for total growth inhibition: 100000 nM
For compound 3 the middle estimate is 10-fold (1.00 log units) below the measured one, and the stated range ends below it.
By their numbers in this assay, from the lowest: compound 1; then compounds 2 and 3 (each within the scatter of the next).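

In this assay, replacing 2-phenylethenyl with 3,4-dimethoxyphenyl on the saturated ring carbon gives a 1.1-fold higher number from compound 2 to compound 3 (0.06 log units; within the scatter), so an aryl ring attached directly at this position is not enough to give the number seen for compound 1. Set against 2-hydroxyphenyl, the same 3,4-dimethoxyphenyl group gives a 23-fold higher number from compound 1 to compound 3 (1.35 log units; beyond the scatter), which leaves compound 1 alone at the low end of the three and shows that the choice of substituents on this ring can matter a great deal. No measurement at hand explains this difference.

As far as these compounds go, it remains open whether the hydroxyl itself accounts for the number of compound 1, or whether its place on the ring also matters. A 2-methoxyphenyl, 4-hydroxyphenyl or 2-aminophenyl group at this carbon would separate these possibilities.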